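A few compounds are considered here, and "the series" means these few. Any claim that something is new, unique, unknown or untested is made for them only; others in the source may bear on it.

Series notes. Compound 1 `O=C(CCl)Nc1cccc(Cn2nc(-c3ccc(Oc4ccccc4)cc3)cc2CO)c1` carries a chloroacetamide and a hydroxymethyl group on the shared core; in a functional assay on Maver1 cells (Homo sapiens) for inhibition, read by luminescence and CellTiter-Glo, with a stated time of 72 h (a higher number here means a weaker inhibitor, a lower number a stronger inhibitor), compound 1 gives 400 nM. Compound 2 `C/C=C/C(=O)Nc1ccc(Cn2nc(-c3ccc(Oc4ccccc4)cc3)cc2C(=O)OCC)cc1` carries a crotonamide and an ethyl ester on the same core. For compound 2 only a limit of the assay is known: in this assay compound 2 gives > 60000 nM. Of the two values shown, this one sits at the upper limit (the limit of > 60000 nM in this assay, at which 1 of the 2 values shown sits), so compound 2 stands as the weaker of the two, and by how much cannot be said from these numbers.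

Compound 3 `C=CC(=O)Nc1ccc(Cn2nc(-c3ccc(Oc4ccccc4)cc3)cc2C(=O)OCC)cc1` is compound 2 with one change: vinyl in place of prop-1-en-1-yl on a carbonyl carbon. The ester and the rest of the core are unchanged. For the measured compounds named here, no measured pair differs in just this place, so there is no measured step to lean on. The expected step is an at least 3.0-fold lower number from compound 2 to compound 3 (0.47 log units; beyond the scatter), toward stronger inhibition. A return to the level of compound 1, 400 nM, is not expected, as compound 3 differs from compound 1 in several places at once. Compound 3 is estimated at 20000 nM in this assay, with a range of 3000 nM to 60000 nM, and a sizeable chance that the assay again reports only a limit.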

Compound 3, half-maximal inhibitory concentration: 13300 nM
Beside the measured number, compound 3's estimate is 1.5-fold (0.18 log units) above it, within the range that was stated.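

The change of prop-1-en-1-yl to vinyl on a carbonyl carbon, with the ethyl ester and the rest of the shared core unchanged, gives an at least 4.5-fold lower number from compound 2 to compound 3 (0.65 log units; beyond the scatter) in this assay, the only measured step at this place among the compounds shown. It shows that the group on this carbonyl carbon alone can carry the series to a readable number. Compound 3 gives 13300 nM while still bearing the ethyl ester. The step can be stated only as a lower bound, and its true size stays unknown, because compound 2 is held by a limit and not by a number: the limit of > 60000 nM in this assay, at which 1 of the 3 values shown sits.

Compound 1 differs from compound 3 in several places at once, so the compounds shown do not separate the share of the chloroacetamide from that of the hydroxymethyl group. Also open, as far as these compounds go, is how the number would move with a carboxylic acid or a primary amide in place of the ethyl ester, or with a dimethylaminomethyl group on the vinyl.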